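Substituent Swap on the Aromatic Nitrogen of a Dichlorophenyl Pyridone Nitrile

The compounds below may be only part of what the source reports. "The series", "measured", "known", "first", "only" and "open" are said of these compounds alone.

The measured compounds, with their numbers in a functional assay on MCF7 cells (Homo sapiens) for cytotoxicity, read by sulforhodamine B assay, with a stated time of 48 h; a lower number here means a stronger inhibitor, a higher number a weaker inhibitor:
compound 1 `N#Cc1c(-c2ccc(Cl)cc2)cc(-c2ccc(Cl)cc2)n([C@@H]2O[C@H](CO)[C@@H](O)[C@H]2O)c1=O` gives 5.7 ug/mL;
compound 2 `C=CCn1c(-c2ccc(Cl)cc2)cc(-c2ccc(Cl)cc2)c(C#N)c1=O` gives 19 ug/mL;
compound 3 `N#Cc1c(-c2ccc(Cl)cc2)cc(-c2ccc(Cl)cc2)n(CC(O)CCl)c1=O` gives 4.6 ug/mL.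

Compound 1 stands second highest of the three numbers. Its nearest neighbour is compound 3, a difference of a 1.2-fold lower number from compound 1 to compound 3 (0.09 log units; within the scatter), which is within the scatter; its furthest is compound 2, a difference of a 3.3-fold higher number from compound 1 to compound 2 (0.52 log units; beyond the scatter), which is beyond it. Between compound 2 and compound 3 the difference is a 4.1-fold lower number from compound 2 to compound 3 (0.62 log units; beyond the scatter).

Compound 4 `CCn1c(-c2ccc(Cl)cc2)cc(-c2ccc(Cl)cc2)c(C#N)c1=O` differs from compound 1 in one place: ethyl in place of 3,4-dihydroxy-5-(hydroxymethyl)oxolan-2-yl on an aromatic nitrogen. Like allyl, ethyl brings no ring and no hydrogen-bond donors or acceptors, so the step from compound 1 to compound 2 bears most directly on it; the step from compound 1 to compound 3, within the scatter, retains hydroxyl and chlorine on the chain and is less comparable. Compound 4 is therefore expected to show a modestly higher number, roughly a 2.6-fold higher number from compound 1 to compound 4 (0.42 log units; beyond the scatter), because of a 3.3-fold higher number from compound 1 to compound 2 (0.52 log units; beyond the scatter). The estimate for compound 4 in this assay is 15 ug/mL, with a range from 7 ug/mL to 35 ug/mL.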

Compound 4, half-maximal inhibitory concentration: 19.7 ug/mL
Compound 4: the middle estimate sits 1.3-fold (0.12 log units) below what was measured; the range from low to high includes it.
By their numbers in this assay, from the lowest: compounds 3 and 1 (each within the scatter of the next); then compounds 2 and 4 (each within the scatter of the next).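

In this assay, a chain ending in methyl reads the same as one ending in vinyl on the aromatic nitrogen (a 1.0-fold higher number from compound 2 to compound 4 (0.02 log units; within the scatter)), so this change at the chain end leaves the number within the scatter. With ethyl, a second small chain without hydroxyl or chlorine now stands apart from both substituted groups, the 3,4-dihydroxy-5-(hydroxymethyl)oxolan-2-yl group (a 3.5-fold higher number from compound 1 to compound 4 (0.54 log units; beyond the scatter)) and the 3-chloro-2-hydroxypropyl group (a 4.3-fold higher number from compound 3 to compound 4 (0.63 log units; beyond the scatter)), each step lying beyond the scatter. Nothing available here accounts for these differences. Whether the hydroxyl or the chlorine of the 3-chloro-2-hydroxypropyl chain matters more stays open, as a plain 2-hydroxypropyl or 3-chloropropyl chain is not among these compounds. As far as these compounds go, how a 3-aminopropyl or a longer butyl chain would read on this nitrogen also stays open.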